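Piperidine-linked propanoic acids: Emax of fluoro-to-isopropyl swap

A few compounds are considered here, and "the series" means these few. Any claim that something is new, unique, unknown or untested is made for them only; others in the source may bear on it.

Measured compounds:
compound 1, `COc1ccc(F)c(-c2ccc(COc3cccc([C@@H](CC(=O)O)C4CC4)c3)nc2CC(C)(C)C)c1`, 66%
compound 2, `COc1ccc(F)c(N2CCC(COc3cccc(C(CC(=O)O)C4CC4)c3)CC2)c1`, 114%

Both compounds were run in a functional assay on cells for agonist activity at Free fatty acid receptor 1 (Homo sapiens), read by FLIPR and calcium flux, with a stated time of 60 min; a higher number here means a larger maximal response, a lower number a smaller maximal response. Compound 1 with structure `COc1ccc(F)c(-c2ccc(COc3cccc([C@@H](CC(=O)O)C4CC4)c3)nc2CC(C)(C)C)c1` gives 66%, while compound 2 with structure `COc1ccc(F)c(N2CCC(COc3cccc(C(CC(=O)O)C4CC4)c3)CC2)c1` gives 114%. Of the two numbers, compound 2 stands highest; the gap to compound 1 lies beyond the usual scatter, so compound 2 reaches the larger maximal response of the pair. Since the two compounds differ in more than one place, no single structural reason for this gap can be read from the data.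

Compound 3, `COc1ccc(C(C)C)c(N2CCC(COc3cccc(C(CC(=O)O)C4CC4)c3)CC2)c1`, has not yet been measured in this assay. It differs from compound 2 as follows: isopropyl in place of fluoro on an aromatic carbon. Within the data shown here, no measured pair in this set shares this change, so its effect on the maximal response is unknown. The expectation is a step from compound 2 to compound 3 of a number 9 percentage points lower from compound 2 to compound 3 (within the scatter), within the scatter, since nothing in the data argues for a shift in either direction. The estimate for compound 3 in this assay is 105%, with a range from 80% to 125%.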

Compound 3, largest response reached (Emax), in percent of the reference or control that the assay uses: 117%
Beside the measured number, compound 3's estimate is 12 percentage points below it, within the range that was stated.
By their numbers in this assay, from the lowest: compound 1; then compounds 2 and 3 (each within the scatter of the next).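

In this assay, isopropyl in place of fluoro on this aromatic carbon, ortho to a large group and para to a methoxy group, gives a number 3 percentage points higher from compound 2 to compound 3 (within the scatter). The earlier compounds shown here offered no single-change comparison, and this first one shows that the maximal response stays high with three carbon atoms in place of one fluorine at this position: compound 2 gives 114% and compound 3 gives 117%, values that cannot be told apart. No measurement shown here offers an explanation for this tolerance.

One pair cannot show whether the tolerance extends to other groups on this carbon, such as an amine, a carboxylic acid or a longer chain like n-butyl. From the compounds shown here alone, it also remains open whether the move from 2-fluoro-5-methoxyphenyl to 2-isopropyl-5-methoxyphenyl would leave the maximal response similarly unchanged on the core of compound 1, which carries the fluoro group and gives 66%.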